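A few compounds are considered here, and "the series" means these few. Any claim that something is new, unique, unknown or untested is made for them only; others in the source may bear on it.

Compound 1, `CC(=O)Nc1ccc(-c2nc3ccccc3[nH]2)cc1`, and compound 2, `O=C(CCl)Nc1ccc(-c2nc3cc(C(F)(F)F)ccc3[nH]2)cc1`, were both examined in an ADME assay on MT4 cells (Homo sapiens) for cytotoxicity, read by MTT assay, with a stated time of 96 h; a lower number here means that less compound is tolerated, a higher number that more compound is tolerated. Compound 1 gives 100000 nM in this assay. Compound 2 gives 5000 nM, the lower of the two values, and the gap to compound 1 lies beyond the scatter. Compound 3, `CCN(CC)CC(=O)Nc1ccc(-c2nc3cc(C(F)(F)F)ccc3[nH]2)cc1`, has not yet been measured; it differs from compound 2 in one place: diethylamino in place of chloro on a saturated chain carbon bound to a carbonyl carbon. For compound 3 in this assay an upward step of an 8.0-fold higher number from compound 2 to compound 3 (0.90 log units; beyond the scatter) is expected. Compound 3 is therefore estimated at 40000 nM, with a range from 10000 nM to 150000 nM.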

Compound 3, half-maximal cytotoxic concentration: 8000 nM
For compound 3 the middle estimate is 5.0-fold (0.70 log units) above the measured one; measured number outside the range, below it.
By their numbers in this assay, from the lowest: compounds 2 and 3 (each within the scatter of the next); then compound 1.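

In this assay, diethylamino in place of chloro on a saturated chain carbon bound to a carbonyl carbon gives a 1.6-fold higher number from compound 2 to compound 3 (0.20 log units; within the scatter). At this position, then, a group of five heavy atoms and a single chlorine cannot be told apart, so the number for compound 2 does not depend on chloro alone. Nothing shown here gives a reason for this result.

Going by these compounds, whether morpholine or a carboxylic acid at this place would also stay within the scatter of compound 2 remains open. So does the contribution of trifluoromethyl, as compound 1 differs from compound 2 in more than one place.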